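Adding a chloro group to a sulfonyl-hydroxyguanidine growth inhibitor

A few compounds are considered here, and "the series" means these few. Any claim that something is new, unique, unknown or untested is made for them only; others in the source may bear on it.

Measured compounds in a functional assay on OVCAR-3 cells (Homo sapiens); a lower number here means a stronger inhibitor of growth, a higher number a weaker inhibitor of growth:
- compound 1 `N=C(NO)NS(=O)(=O)c1cc(-c2nnc(-c3ccc(Cl)cc3)s2)c(Cl)cc1SCc1ccccc1`: 1670 nM
- compound 2 `COc1cc(CSc2cc(Cl)c(-c3nc(-c4ccccc4)no3)cc2S(=O)(=O)NC(=N)NO)cc(OC)c1OC`: 4790 nM
- compound 3 `N=C(NO)NS(=O)(=O)c1cc(-c2nc(-c3ccccc3)no2)c(Cl)cc1SCc1ccccc1`: 1690 nM

Among these three, compound 2 gives the highest number in this assay, which means it is the weakest growth inhibitor of the set. Its nearest neighbour is compound 3, reached by a 2.8-fold lower number from compound 2 to compound 3 (0.45 log units; beyond the scatter), a change on the saturated chain carbon bound to a sulfur. Compound 1 lies slightly further away, though compound 1 and compound 3 themselves give numbers that sit within the usual scatter of each other.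

The unmeasured compound 4 `COc1cc(CSc2cc(Cl)c(-c3nc(-c4ccc(Cl)cc4)no3)cc2S(=O)(=O)NC(=N)NO)cc(OC)c1OC` differs from compound 2 in one place: chloro in place of hydrogen on an aromatic carbon. Among the measured compounds shown here, no measured pair isolates exactly this change. For the measured compounds named here, the only hint comes from compound 1 and compound 3, which differ by a chloro group together with a different five-membered ring and yet give almost the same number. That hint is weak, since two things change at once.

On this basis no step beyond the scatter is expected, and compound 4 is estimated at 4000 nM, within 1800 nM to 9000 nM. The expected step from compound 2 is therefore a 1.2-fold lower number from compound 2 to compound 4 (0.08 log units; within the scatter).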

Compound 4, concentration for 50% growth inhibition: 1910 nM
Beside the measured number, compound 4's estimate is 2.1-fold (0.32 log units) above it; the range from low to high includes it.
By their numbers in this assay, from the lowest: compounds 1, 3 and 4 (each within the scatter of the next); then compound 2.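

In this assay, changing phenyl to 4-chlorophenyl gives a 2.5-fold lower number from compound 2 to compound 4 (0.40 log units; beyond the scatter), so a single added chlorine atom on this aromatic carbon is enough to move the number beyond the scatter, a modest gain in growth inhibition. Among the compounds shown here, compound 2 can therefore be improved by a one-place change at this ring as well as at the 3,4,5-trimethoxyphenyl group, where replacement by phenyl gives a 2.8-fold lower number from compound 2 to compound 3 (0.45 log units; beyond the scatter), and the earlier compounds could not show the effect of the chloro group alone. No measurement shown accounts for the effect of this chloro group on growth inhibition.

The compounds shown leave open whether the same chloro group would lower the number when the sulfur carries a plain benzyl group rather than the 3,4,5-trimethoxybenzyl group of compound 2 and compound 4. They also leave open whether this gain is specific to chloro or would also appear with another group on the same carbon, such as fluoro, bromo or trifluoromethyl.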